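Cyclobutyl to oxetanyl: an untested ring swap

The source may hold more compounds than are shown below. What is called first, only, known or untested is meant among the compounds shown, and "the series" means these compounds.

Compound 2 `Cc1cc(-c2ccnc3[nH]nc(C(F)(F)F)c23)cc(C2(CN)CCC2)c1` gives 3 nM in an assay for inhibition of protein kinase C theta type (Homo sapiens), read by scintillation counting and 33P incorporation, with a stated time of 60 min, in the presence of a further agent that is not named here; a higher number here means a weaker inhibitor, a lower number a stronger inhibitor. Compound 3 `NCC1(c2cccc(-c3ccnc4[nH]nc(C(F)(F)F)c34)c2)CCC1` gives 2 nM, and the step of a 1.5-fold lower number from compound 2 to compound 3 (0.18 log units; within the scatter) lies within the scatter. Compound 1 `NCC1(c2cccc(-c3ccnc4[nH]ncc34)c2)CCOCC1` gives 9 nM, so compound 2 sits second highest among these three numbers. Compound 4 `Cc1cc(-c2ccnc3[nH]nc(C(F)(F)F)c23)cc(C2(CN)COC2)c1` carries the change (3-(aminomethyl)oxetan-3-yl in place of 1-(aminomethyl)cyclobutyl on an aromatic carbon). Among the measured compounds shown here, no measured step here touches that ring: the only step available, a 1.5-fold lower number from compound 2 to compound 3 (0.18 log units; within the scatter), concerns a methyl group and says nothing about exchanging the carbon ring for one holding an oxygen. The expectation is therefore a modest change, a 1.7-fold higher number from compound 2 to compound 4 (0.22 log units; within the scatter), not clearly beyond the scatter. Compound 4 is estimated at 5 nM in this assay, with a range from 2 nM to 15 nM.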

Compound 4, inhibition constant in the protein kinase C theta type assay: 8 nM
Beside the measured number, compound 4's estimate is 1.6-fold (0.20 log units) below it, and the stated range covers the measured number.
By their numbers in the protein kinase C theta type assay, from the lowest: compounds 3 and 2 (each within the scatter of the next); then compounds 4 and 1 (each within the scatter of the next).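

In the protein kinase C theta type assay, the first change shown to this ring gives a step beyond the scatter, a 2.7-fold higher number from compound 2 to compound 4 (0.43 log units; beyond the scatter), so the exchange of 1-(aminomethyl)cyclobutyl for 3-(aminomethyl)oxetan-3-yl is not silent at this position. In a physicochemical assay for acid dissociation, compound 2 gives 8.8 and compound 4 gives 7.9. In the physicochemical assay, the same exchange also moves the reading: the measured acid dissociation constant of compound 2, 8.8, and of compound 4, 7.9, a number 0.90 log units lower (beyond the scatter)

Two compounds cannot show whether this shift and the weaker inhibition are linked. Nor do they show how a fluorine atom on the cyclobutyl ring, or an aminoethyl chain in place of aminomethyl, would behave in either assay.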